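Extending a methyl to an ethyl on a shared core

The source may hold more compounds than are shown below. What is called first, only, known or untested is meant among the compounds shown, and "the series" means these compounds.

Two compounds share one core and differ only in a single group on an aromatic carbon. Compound 1 `COc1ccc(C2=NOC(C)(C)C2=O)cc1-c1cnc(NC(=O)c2c(F)cccc2F)cn1` carries a methoxy there, and in an assay on Jurkat T cells for inhibition of interleukin-2 (Homo sapiens), read by ELISA, with stated times of 10 min and 24 h (on this read-out higher numbers stand for weaker inhibition and lower numbers for stronger inhibition), compound 1 gives 50 nM. Compound 2 `Cc1ccc(C2=NOC(C)(C)C2=O)cc1-c1cnc(NC(=O)c2c(F)cccc2F)cn1` carries a methyl in its place, and in this assay compound 2 gives 34 nM. The change between them is a 1.5-fold lower number from compound 1 to compound 2 (0.17 log units; within the scatter), so compound 2 stands on the lower of the two numbers shown, yet it is not separated from compound 1 beyond the scatter.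

Compound 3 `CCc1ccc(C2=NOC(C)(C)C2=O)cc1-c1cnc(NC(=O)c2c(F)cccc2F)cn1` has not been measured. It differs from compound 2 by methyl in place of hydrogen on a saturated chain carbon bound to an aromatic carbon. Among the compounds with values here, the only measured step that bears on this is the exchange of methoxy for methyl on the same aromatic carbon, which stayed within the scatter. On that basis the expected step in this assay is a 1.0-fold higher number from compound 2 to compound 3 (0.01 log units; within the scatter), not larger than the scatter and with no settled direction. For compound 3 the estimated value in this assay is 35 nM, with a range from 15 nM to 85 nM.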

Compound 3, half-maximal inhibitory concentration: 32 nM
Compound 3: the middle estimate sits 1.1-fold (0.04 log units) above what was measured; low and high end bracket the measured number.
By their numbers in this assay, from the lowest: compounds 3, 2 and 1 (each within the scatter of the next).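

In this assay, extending the methyl to an ethyl on this aromatic carbon gives a 1.1-fold lower number from compound 2 to compound 3 (0.03 log units; within the scatter) and so stays inside the usual scatter of the measurement, which means that one extra carbon on the chain at this place produces no change that can be read. Set against the methoxy of the first compound, the ethyl gives a 1.6-fold lower number from compound 1 to compound 3 (0.19 log units; within the scatter) and also stays inside the scatter, so methoxy, methyl and ethyl now all sit within the scatter of one another, and the position has kept its numbers through a lengthened chain as well as through an exchange of one small group for another. Nothing accompanies these numbers that could explain why the three groups read alike.

From the compounds shown here alone, it remains open how far this holds for a longer chain such as propyl, for a branched group such as isopropyl, or for a charged group such as an amine or a carboxylic acid on the same aromatic carbon. Going by these compounds, it also remains open what plain hydrogen at this place would give, and so whether any group there matters for the read-out at all.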